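Swapping 2,4-dichlorophenyl for 3,4-dichlorophenyl

The source may report more compounds than this note shows. Statements on the series, on what has been measured and on what is new or still open speak of the compounds shown alone.

In a functional assay on SW-620 cells (Homo sapiens) for cytotoxicity, read by MTT assay, with a stated time of 72 h (on this read-out lower numbers stand for stronger inhibition and higher numbers for weaker inhibition), compound 1 `COc1ccc(/C=C2\CCC/C(=C\c3cccc(OC)c3OC)C2=O)cc1` gives 13600 nM, and compound 2 `COc1cccc(/C=C2\CCC/C(=C\c3ccc(Cl)cc3Cl)C2=O)c1OC` gives 16300 nM. Going by the values given here, the only measured step is a 1.2-fold higher number from compound 1 to compound 2 (0.08 log units; within the scatter), so compound 2 stands level on these numbers. Compound 3 `COc1cccc(/C=C2\CCC/C(=C\c3ccc(Cl)c(Cl)c3)C2=O)c1OC` differs from compound 2 in one group: 3,4-dichlorophenyl in place of 2,4-dichlorophenyl on a double-bonded chain carbon bound to a double-bonded ring carbon. Among the compounds with values here, that measured step exchanged a different pair of groups at this same place, and it stayed small, so it is the only guide here. No change beyond the scatter is expected in this assay. The expected step is a 1.1-fold lower number from compound 2 to compound 3 (0.04 log units; within the scatter). Compound 3 is estimated at 15000 nM, within an expected range of 6500 nM to 35000 nM.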

Compound 3, half-maximal inhibitory concentration: 10000 nM
Estimate against measurement, compound 3: 1.5-fold (0.18 log units) above, and the stated range covers the measured number.
By their numbers in this assay, from the lowest: compounds 3, 1 and 2 (each within the scatter of the next).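

In this assay, 3,4-dichlorophenyl in place of 2,4-dichlorophenyl gives a 1.6-fold lower number from compound 2 to compound 3 (0.21 log units; within the scatter), so the two chlorine patterns shown cannot be told apart at this place. With 3,4-dichlorophenyl in place of 4-methoxyphenyl, the reading is a 1.4-fold lower number from compound 1 to compound 3 (0.13 log units; within the scatter), so all three aromatic groups now read alike here. No measurement offered here bears on why these numbers lie so close. On these data alone, whether an amine, a carboxylic acid or a pyridine ring at this place would move the number beyond the scatter remains open.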